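This account rests on a few compounds, and the source may have more. Where it says the series, first, only, none or still open, it means among the compounds named here.

For the measured compounds named here, in a physicochemical assay, with a stated time of 6 min (on this read-out lower numbers stand for stronger inhibition and higher numbers for weaker inhibition), compound 2 (`COc1cccc(NC(=O)Nc2nc(-c3cc4ccccc4o3)cs2)c1`) gives 200 nM and holds the lower of the two numbers so far, while compound 1 (`O=C(Nc1nc(-c2cc3ccccc3o2)cs1)Nc1ccccc1F`) gives 2630 nM in the same read-out. Going by the values given here, the only measured step is large, a 13-fold lower number from compound 1 to compound 2 (1.12 log units; beyond the scatter) on the aryl group, but it involves no chloro. Compound 3 (`O=C(Nc1cccc(Cl)c1)Nc1nc(-c2cc3ccccc3o2)cs1`) differs from compound 2 by chloro in place of methoxy on an aromatic carbon as chloro in place of methoxy on an aromatic carbon, meta to a large group. Among the compounds with values here, no measured step covers this exchange, so only a small rise is expected, an estimated 1.5-fold higher number from compound 2 to compound 3 (0.18 log units; within the scatter) in this assay with no change beyond the scatter firmly predicted. For compound 3 the expected value is 300 nM (estimated range 90 nM to 1000 nM).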

Compound 3, half-maximal inhibitory concentration: 14100 nM
The estimate for compound 3 lay 47-fold (1.67 log units) below the measured number; the whole stated range lies below it.
By their numbers in this assay, from the lowest: compound 2; then compound 1; then compound 3.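

At this aromatic carbon, the exchange of methoxy for chloro is far from neutral: in this assay it brings a large loss of inhibition (a 71-fold higher number from compound 2 to compound 3 (1.85 log units; beyond the scatter)). For the compounds shown here, the 3-chlorophenyl group also reads weaker than the 2-fluorophenyl group (a 5.4-fold higher number from compound 1 to compound 3 (0.73 log units; beyond the scatter)), so on these three compounds 3-methoxyphenyl is the only aryl group giving a low number. Nothing at hand explains the size of this change.

The compounds shown leave open whether methoxy is itself required here, or whether an amine or an ethoxy group on this carbon would hold the number of compound 2.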